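This account rests on a few compounds, and the source may have more. Where it says the series, first, only, none or still open, it means among the compounds named here.

Compound 1 `Cn1c(-c2cccnc2)nc2ccc(F)cc21` carries a methyl on its ring nitrogen and a fluorine on the fused benzene. In an assay on V79 cells for inhibition of cytochrome P450 11B2, mitochondrial (Homo sapiens), read by HTRF, with a stated time of 1 h (on this read-out higher numbers stand for weaker inhibition and lower numbers for stronger inhibition), compound 1 gives 12 nM, which is the highest of the two numbers recorded; the nearest is compound 2 `N#Cc1cc2c(cc1F)nc(-c1cccnc1)n2C1CC1`, whose value of 0.6 nM lies well beyond the usual scatter of such repeats. Compound 3 `FC(F)(F)c1ccc2c(c1)nc(-c1cccnc1)n2C1CC1` bears a trifluoromethyl in place of the nitrile-and-fluorine pattern, and for compound 3 this assay reports only a limit of > 10000 nM, not a number. That limit, (the limit of > 10000 nM in this assay, at which 1 of the 3 values shown sits), marks the ceiling of what this assay can resolve.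

The step to compound 4 `CCn1c(-c2cccnc2)nc2ccc(F)cc21` is small in structure: methyl in place of hydrogen on a saturated chain carbon bound to an aromatic nitrogen, which read one bond further out is methyl to ethyl on the ring nitrogen. Among the compounds with values here, no measured pair differing only in this way exists among the compounds at hand, so the size of the step must be judged from the change itself. Since a single carbon is added to a saturated chain and no ring, donor or acceptor enters, a step in this assay that stays within the scatter, in either direction or none at all, is what is expected. Compound 4 is therefore expected to land close to compound 1, at an estimated 10 nM with a likely span from 3 nM to 40 nM, an expected step of a 1.2-fold lower number from compound 1 to compound 4 (0.08 log units; within the scatter).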

Compound 4, half-maximal inhibitory concentration: 35 nM
Compound 4: the middle estimate sits 3.5-fold (0.54 log units) below what was measured, and the stated range covers the measured number.
By their numbers in this assay, from the lowest: compound 2; then compound 1; then compound 4. At a limit, above all of these: compound 3.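

In this assay, the change from methyl to ethyl on the ring nitrogen gives a 2.9-fold higher number from compound 1 to compound 4 (0.46 log units; beyond the scatter), so this place, on a saturated chain carbon bound to an aromatic nitrogen, responds to the addition of a single carbon, even though no ring, donor or acceptor enters. Within the data shown here, compounds 1, 2 and 3 differ from one another in more than one place and could not isolate any single position, which makes this the first step that can be read for one change alone. The step is modest and rests on a single pair, and nothing measured here bears on why the number rises with this change.

On these data alone, it remains open whether a longer chain such as propyl, or a chain ending in an amine or a hydroxyl, would carry the number further up, hold it level or bring it back down. It is equally open whether the methyl to ethyl change would have a step of similar size on the core of compound 2, where the fluorine is joined by a nitrile, since the one pair shown speaks only for the core of compound 1.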